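The compounds below may be only part of what the source reports. "The series", "measured", "known", "first", "only" and "open" are said of these compounds alone.

Measured compounds:
compound 1 `Oc1ccc(-c2cc(-c3ccco3)cc(-c3ccccc3O)n2)cc1` — 0%
compound 2 `Oc1ccccc1-c1cc(-c2ccoc2)cc(-c2ccccc2O)n1` — "not determined" (no result reported)

Compound 2 stands without a number: in an assay on isolated protein for inhibition of DNA topoisomerase 1 (Homo sapiens), with a stated time of 30 min, tested at 20 uM (a higher number here means a stronger effect of the compound at the concentration tested, a lower number a weaker effect), compound 2 gives "not determined" (no result reported), so it offers no anchor. Within the data shown here, the only value in the set is that of compound 1, which in this assay gives 0%. Compound 3 `Oc1ccc(-c2cc(-c3ccoc3)cc(-c3ccccc3O)n2)cc1` differs from compound 2 by 4-hydroxyphenyl in place of 2-hydroxyphenyl on an aromatic carbon. Among the measured compounds shown here, no comparable step has been measured; since compound 1 carries the same 4-hydroxyphenyl arrangement and shows no inhibition, no shift beyond the scatter is expected in this assay for this change. Compound 3 is therefore estimated at 4%, within 0% to 20%.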

Compound 3, a percentage reported as inhibition, at one concentration (the size of the read-out at that concentration, not a potency): 3.9%
The estimate for compound 3 lay 0.1 percentage points above the measured number; measured number inside the range.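

In this assay, furan-3-yl in place of furan-2-yl gives a number 3.9 percentage points higher from compound 1 to compound 3 (within the scatter), so the two furan attachments are not told apart when 4-hydroxyphenyl sits on the shared core. Compound 3, at 3.9%, extends the low read-out of compound 1 to a second furan attachment. No measured evidence bears on this result.

On these data alone, the step from compound 2 to compound 3 cannot be read, so the effect of moving the hydroxyl from 2-hydroxyphenyl to 4-hydroxyphenyl stays open. Also open, as far as these compounds go, is whether an amine or a carboxylic acid on this aromatic carbon would give any inhibition.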